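A few compounds are considered here, and "the series" means these few. Any claim that something is new, unique, unknown or untested is made for them only; others in the source may bear on it.

In a functional assay for inhibition, with Homo sapiens as the target (on this read-out higher numbers stand for weaker inhibition and lower numbers for stronger inhibition), compound 1 `CCCCCS(=O)(=O)N[C@@H](CNC(=O)c1ccc2c(c1)C(=O)N(CCC1CCNCC1)C2)C(=O)O` gives 9 nM and compound 2 `O=C(NC[C@H](NS(=O)(=O)c1cccnc1)C(=O)O)c1ccc2c(c1)C(=O)N(CCC1CCNCC1)C2` gives 15 nM, values within the usual scatter of each other. Compound 3 `O=C(O)c1ccc(S(=O)(=O)N[C@@H](CNC(=O)c2ccc3c(c2)C(=O)N(CCC2CCNCC2)C3)C(=O)O)cc1` changes the group on the sulfonyl sulfur again, with 4-carboxyphenyl in place of pyridin-3-yl on a sulfonyl sulfur. Going by the values given here, the only measured step at this place is a 1.7-fold higher number from compound 1 to compound 2 (0.22 log units; within the scatter), which stayed within the scatter. No step beyond the scatter is therefore expected in this assay, though a single step is thin evidence for a group that enters with a carboxyl. The estimate implies a 1.1-fold lower number from compound 2 to compound 3 (0.03 log units; within the scatter). For compound 3 the expected value is 14 nM, with an estimated range of 5 nM to 40 nM.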

Compound 3, half-maximal inhibitory concentration: 7 nM
Compound 3: the middle estimate sits 2.0-fold (0.30 log units) above what was measured, within the range that was stated.
By their numbers in this assay, from the lowest: compounds 3, 1 and 2 (each within the scatter of the next, the first and the last beyond it).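

In this assay, this place on the sulfonyl sulfur gives its first step beyond the scatter, though a modest one: a 2.1-fold lower number from compound 2 to compound 3 (0.33 log units; beyond the scatter). The 4-carboxyphenyl group also stays level with pentyl, with a 1.3-fold lower number from compound 1 to compound 3 (0.11 log units; within the scatter), so a group entering with a carboxyl keeps the number within the scatter of the pentyl compound. Nothing at hand explains either step.

The compounds shown leave open whether the carboxylic acid or the carbon-only ring accounts for the step from pyridin-3-yl, which an unsubstituted phenyl would separate. As far as these compounds go, how a shorter chain such as methyl, or a phenyl carrying an amine, would read at this place also stays open.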